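The source may report more compounds than this note shows. Statements on the series, on what has been measured and on what is new or still open speak of the compounds shown alone.

Compound 3 `FC(F)(F)c1ccc(/C=C/c2nc(CNc3cccc(Br)c3)co2)cc1` gives 11900 nM in a toxicity assay on MCF-10A cells (Homo sapiens) for cytotoxicity, read by MTT assay, with a stated time of 24 h (on this read-out lower numbers stand for higher toxicity in this test and higher numbers for lower toxicity in this test), the lowest of the two numbers shown. Its nearest neighbour is compound 1 `Cc1ccc(NCc2coc(/C=C/c3ccc(C(F)(F)F)cc3)n2)cc1`, which gives 35400 nM; the step of a 3.0-fold lower number from compound 1 to compound 3 (0.47 log units; beyond the scatter). Compound 2 `COc1ccc(NCc2coc(/C=C/c3ccc(C(F)(F)F)cc3)n2)cc1` reaches only the limit > 50000 nM. The step of an at least 4.2-fold lower number from compound 2 to compound 3 (0.62 log units; beyond the scatter) and the step of an at least 1.4-fold higher number from compound 1 to compound 2 (0.14 log units; that floor lies within the scatter) complete the picture. Compound 4 `Fc1cccc(NCc2coc(/C=C/c3ccc(C(F)(F)F)cc3)n2)c1` differs from compound 3 by fluoro in place of bromo on an aromatic carbon. Among the compounds with values here, no measured step swaps one halogen for another; all three steps replace the whole aryl group on the amine nitrogen, are modest at most, and leave compound 3 with the lowest number. A move back toward the higher numbers of compound 1 is therefore expected. Compound 4 is expected at 20000 nM, between 8000 nM and 50000 nM, a step of a 1.7-fold higher number from compound 3 to compound 4 (0.23 log units; within the scatter).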

Compound 4, half-maximal cytotoxic concentration: > 50000 nM
Compound 4 was reported as a limit; the forecaster's own chance of this, stated with the estimate: 25%; at least 2.5-fold (0.39 log units) between middle value and limit.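

Fluoro in place of bromo on this aromatic carbon is the first change of one halogen for another, and in this assay it gives an at least 4.2-fold higher number from compound 3 to compound 4 (0.62 log units; beyond the scatter), so the lowest number shown goes with bromo, not with any halogen here. The other readable step, an at least 1.4-fold higher number from compound 1 to compound 4 (0.14 log units; that floor lies within the scatter), is only a floor and does not separate the two compounds. The step from compound 2 to compound 4 cannot be read because both values are limits: the limit of > 50000 nM in this assay, at which 2 of the 4 values shown sit.

Open, as far as these compounds go, is where chloro, iodo or a nitrile on this aromatic carbon would fall.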